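Chloro-to-methoxy exchange on the benzoate, carried to a substituted core

The source may report more compounds than this note shows. Statements on the series, on what has been measured and on what is new or still open speak of the compounds shown alone.

Compound 1 `O=C1CCCC/C1=C\c1ccc(OC(=O)c2ccc(Cl)cc2)cc1` is the reference of the series. In a functional assay on L1210 cells (Mus musculus) (a lower number here means a stronger inhibitor, a higher number a weaker inhibitor), compound 1 gives 3330 nM. Compound 2 `COc1ccc(C(=O)Oc2ccc(/C=C3\CCCCC3=O)cc2)cc1` carries the change methoxy in place of chloro on an aromatic carbon and in this assay compound 2 gives 43400 nM, a step of a 13-fold higher number from compound 1 to compound 2 (1.12 log units; beyond the scatter). Compound 3 `CN(C)CC1CCC/C(=C\c2ccc(OC(=O)c3ccc(Cl)cc3)cc2)C1=O` differs from compound 1 by (dimethylamino)methyl in place of hydrogen on a saturated ring carbon; in this assay compound 3 gives 5610 nM, a step of a 1.7-fold higher number from compound 1 to compound 3 (0.23 log units; within the scatter). Compound 4 `COc1ccc(C(=O)Oc2ccc(/C=C3\CCCC(CN(C)C)C3=O)cc2)cc1` has not been measured; it differs from compound 3 by methoxy in place of chloro on an aromatic carbon, the same change as from compound 1 to compound 2 at the same place, now applied to the core of compound 3 rather than that of compound 1. The two cores differ by (dimethylamino)methyl in place of hydrogen on a saturated ring carbon, which by itself left the number close to that of compound 1. Among the compounds with values here, the expectation for compound 4 therefore rests on the one observed instance, namely the step of a 13-fold higher number from compound 1 to compound 2 (1.12 log units; beyond the scatter), read off from compound 3 with its value 5610 nM. The expected step in this assay is an 11-fold higher number from compound 3 to compound 4 (1.03 log units; beyond the scatter), carried over from the measured pair. Compound 4 is estimated at 60000 nM, with a plausible range from 20000 nM to 180000 nM.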

Compound 4, half-maximal inhibitory concentration: 2870 nM
The estimate for compound 4 lay 21-fold (1.32 log units) above the measured number, and the stated range ends above it.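

In this assay, the chloro-to-methoxy change does not carry over from the core of compound 1 to the core of compound 3; here the step is a 2.0-fold lower number from compound 3 to compound 4 (0.29 log units; within the scatter), and the two instances differ: the same change on two cores in this assay, a 13-fold higher number (1.12 log units; beyond the scatter) from compound 1 to compound 2 and a 2.0-fold lower number (0.29 log units; within the scatter) from compound 3 to compound 4, 25-fold (1.41 log units) apart, beyond the scatter of two such steps. Seen from the other direction, adding (dimethylamino)methyl on the methoxy side gives a 15-fold lower number from compound 2 to compound 4 (1.18 log units; beyond the scatter), and this also differs from the step on the chloro side: the same change on two cores in this assay, a 1.7-fold higher number (0.23 log units; within the scatter) from compound 1 to compound 3 and a 15-fold lower number (1.18 log units; beyond the scatter) from compound 2 to compound 4, 25-fold (1.41 log units) apart, beyond the scatter of two such steps. The two changes are therefore not additive across these four compounds, but this rests on a single pair of cores and a single pair of benzoate substituents, and it does not show why the steps differ or how the change would behave on another core.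

From the compounds shown here alone, it remains open whether other groups in place of chloro, such as fluoro or methyl, would follow the large step seen on the core of compound 1 or the absence of a clear step on the core of compound 3. Going by these compounds, it is also open whether a cyclic amine such as piperidine, in place of the dimethylamino group, would give the same dependence on the benzoate substituent.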